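Capping the Phenol Oxygen of Compound 1: Expected Tolerance

The source may report more compounds than this note shows. Statements on the series, on what has been measured and on what is new or still open speak of the compounds shown alone.

Compound 1 `COc1cc(-c2nnc(SCc3ccccc3F)o2)ccc1O` was tested in an ADME assay on cells (Mus musculus, strain BALB/c) for cytotoxicity, read by MTT assay, with a stated time of 24 h (a lower number here means that less compound is tolerated, a higher number that more compound is tolerated), where compound 1 gives 474000 nM. Compound 2 `COc1cc(-c2nnc(SCc3ccc(Br)cc3)o2)ccc1O` gives 455000 nM, so compound 1 sits alongside compound 2, their step of a 1.0-fold lower number from compound 1 to compound 2 (0.02 log units; within the scatter) being within the scatter. That step swaps the group on the saturated chain carbon bound to a sulfur, a different part of the shared core from the change now considered. Compound 3 `COc1cc(-c2nnc(SCc3ccccc3F)o2)ccc1OCc1ccccc1F` differs from compound 1 by 2-fluorobenzyl in place of hydrogen on an oxygen on an aromatic ring. Among the measured compounds shown here, no measured step touches this oxygen, so the expectation rests on compound 1 at 474000 nM. Compound 3 is therefore estimated at 350000 nM, a step of a 1.4-fold lower number from compound 1 to compound 3 (0.13 log units; within the scatter), with a range from 120000 nM to 1000000 nM.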

Compound 3, half-maximal cytotoxic concentration: 171000 nM
For compound 3 the middle estimate is 2.0-fold (0.31 log units) above the measured one; measured number inside the range.
By their numbers in this assay, from the lowest: compound 3; then compounds 2 and 1 (each within the scatter of the next).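

In this assay, the oxygen on the aromatic ring turns out to be a place where a change registers: 2-fluorobenzyl in place of hydrogen gives a 2.8-fold lower number from compound 1 to compound 3 (0.44 log units; beyond the scatter) and so less compound is tolerated. Among the compounds shown here, this is the first step here to lie beyond the scatter, though it remains modest. Nothing available accounts for this drop.

On these data alone, whether a methyl group or a chain ending in an amine on this oxygen would shift the number in the same way stays open. So does the part played by the fluorine within 2-fluorobenzyl, which plain benzyl could address.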